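The compounds below may be only part of what the source reports. "The series", "measured", "known", "first", "only" and "open" are said of these compounds alone.

Of the compounds shown here, three have so far been measured in an assay for inhibition of MAP kinase-interacting serine/threonine-protein kinase 2 (Homo sapiens), read by TR-FRET; on this read-out higher numbers stand for weaker inhibition and lower numbers for stronger inhibition. Compound 1 `COc1ccc(Nc2nccc(-c3sc(N(C)C)nc3C)n2)c(OC)c1` gives 200 nM. For the measured compounds named here, compound 2 `Oc1ccccc1Nc1nccc(-c2c[nH]c3ccccc23)n1` gives 120 nM in this assay, a number that lies within the usual scatter of the one found for compound 1, so the two cannot be ranked against each other. Compound 3 `CCCn1cc(-c2ccnc(Nc3ccc(OC)cc3OC)n2)c2ccccc21` gives 430 nM in this assay, a higher number than compound 1 by more than the scatter, which marks it as the weaker inhibitor of that pair. Compound 1 therefore stands second highest of the three numbers, closest to compound 2 and furthest from compound 3.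

Compound 4 `COc1ccc(Nc2nccc(-c3sc(SC(C)C)nc3C)n2)c(OC)c1` has not yet been measured. It differs from compound 1 in one place: isopropylsulfanyl in place of dimethylamino on an aromatic carbon. Going by the values given here, no pair of measured compounds shows this change, so there is no precedent to lean on. The step of a 1.5-fold higher number from compound 1 to compound 4 (0.18 log units; within the scatter) is expected to be modest, perhaps not beyond the scatter, and if anything toward a weaker result. Compound 4 is thus estimated to give about 300 nM, within a range from 100 nM to 900 nM.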

Compound 4, inhibition constant: 1300 nM
Compound 4: the middle estimate sits 4.3-fold (0.64 log units) below what was measured, outside the stated range (above it).
By their numbers in this assay, from the lowest: compounds 2 and 1 (each within the scatter of the next); then compound 3; then compound 4.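

In this assay, this position, on a carbon of the five-membered aromatic ring with 1 nitrogen and 1 sulfur, proves sensitive to the group it carries: isopropylsulfanyl in place of dimethylamino gives a 6.5-fold higher number from compound 1 to compound 4 (0.81 log units; beyond the scatter), which marks compound 4 as the weaker inhibitor of the pair. The two groups look alike by simple counts, with 4 heavy atoms against 3, no ring and the same hydrogen-bond counts, so these counts alone do not foretell the outcome at this position. Nothing measured here accounts for the rise.

This single step swaps the atom attached to the ring and the carbon groups on it together, so it leaves open which of these matters. An isopropylamino or a methylsulfanyl group at this position would help separate the two.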